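Swapping the Chlorophenyl on the Core for a Fluorophenyl

The source may report more compounds than this note shows. Statements on the series, on what has been measured and on what is new or still open speak of the compounds shown alone.

Measured in an in vitro assay on HEK385-7 cells for displacement of a labelled ligand from prostaglandin D2 receptor 2 (Homo sapiens); a lower number here means a stronger inhibitor, a higher number a weaker inhibitor:
compound 1 `O=C(O)Cc1sc(C(c2ccccc2)c2ccc(F)cc2)nc1-c1ccc(Cl)cc1` gives 17 nM
compound 2 `O=C(O)Cc1sc(C(c2ccc(F)cc2)c2ccc(F)cc2)nc1-c1ccc(Cl)cc1` gives 9.7 nM
compound 3 `O=C(O)Cc1sc(C(c2ccccc2)c2ccc(O)cc2)nc1-c1ccc(F)cc1` gives 3.4 nM

Compound 2 stands second highest of the three numbers. Its step of a 1.8-fold lower number from compound 1 to compound 2 (0.24 log units; within the scatter) lies within the scatter, so compounds 1 and 2 cannot be set apart. Compound 3 shows a lower number, and that gap lies beyond the scatter, though compound 3 differs from compound 2 in two places at once.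

Compound 4 `O=C(O)Cc1sc(C(c2ccc(F)cc2)c2ccc(F)cc2)nc1-c1cccc(F)c1` differs from compound 2 by 3-fluorophenyl in place of 4-chlorophenyl on an aromatic carbon. Among the compounds with values here, no measured step changes this group alone; the only single step known, a 1.8-fold lower number from compound 1 to compound 2 (0.24 log units; within the scatter), concerns another ring and is within the scatter. Compound 4 is therefore expected near compound 2, with a 1.2-fold higher number from compound 2 to compound 4 (0.09 log units; within the scatter) not beyond the scatter. The estimate for compound 4 in this assay is 12 nM, ranging from 5 nM to 30 nM.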

Compound 4, half-maximal inhibitory concentration: 1.4 nM
Compound 4: the middle estimate sits 8.6-fold (0.93 log units) above what was measured; the whole stated range lies above it.
By their numbers in this assay, from the lowest: compound 4; then compound 3; then compounds 2 and 1 (each within the scatter of the next).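

In this assay, replacing the 4-chlorophenyl with 3-fluorophenyl gives a 6.9-fold lower number from compound 2 to compound 4 (0.84 log units; beyond the scatter), the first single change shown at this position next to the ring nitrogen. Within the data shown here, the step lies beyond the scatter, so this position can separate two compounds, which the only earlier step, a 1.8-fold lower number from compound 1 to compound 2 (0.24 log units; within the scatter), on another ring, could not do. No available measurement accounts for this step.

The compounds shown leave open whether the identity of the halogen or its place on the phenyl ring carries the step. A 3-chlorophenyl group at this position would separate the two.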